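Swapping a Nitro Group for a Sulfone: Expected Polarity

This account rests on a few compounds, and the source may have more. Where it says the series, first, only, none or still open, it means among the compounds named here.

Measured so far in a physicochemical assay for lipophilicity; a lower number here means a more polar compound, a higher number a more lipophilic compound:
compound 1 `C[n+]1ccn(CCCC(C)(C)[N+](=O)[O-])c1/C=N/O`: -2.18
compound 2 `CC[n+]1ccn(COCC(C)(C)[N+](=O)[O-])c1/C=N/O`: -1.77
compound 3 `C[n+]1ccn(CCCCS(C)(=O)=O)c1/C=N/O`: -3.4

Compound 3 differs from compound 1 in one place, ((methylsulfonyl)methyl in place of 1-methyl-1-nitroethyl on a saturated chain carbon, three bonds along the chain from an aromatic nitrogen). In this assay that step was a number 1.22 log units lower from compound 1 to compound 3 (beyond the scatter). Compound 2 has a different core, and how its core differs from that of compound 1 is not broken down here. Compound 4 `CC[n+]1ccn(COCCS(C)(=O)=O)c1/C=N/O` has not yet been measured in this assay. It differs from compound 2 by (methylsulfonyl)methyl in place of 1-methyl-1-nitroethyl on a saturated chain carbon bound to an oxygen on a saturated carbon. The surroundings are not identical: in compound 1 the group sits on a saturated chain carbon, three bonds along the chain from an aromatic nitrogen, whereas in compound 2 it sits on a saturated chain carbon bound to an oxygen on a saturated carbon, so this is the same kind of change, not the same change. Because the earlier step of a number 1.22 log units lower from compound 1 to compound 3 (beyond the scatter) was large, a step of similar size is expected, a number 1.18 log units lower from compound 2 to compound 4 (beyond the scatter). Starting from the value of compound 2, -1.77, compound 4 is expected to give about -2.95, somewhere between -3.5 and -2.4.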

Compound 4, distribution coefficient: < -3
Compound 4 ended at the assay's limit (the forecaster's own chance of this, stated with the estimate: 5%); at least 0.05 log units between middle value and limit.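

In this assay compound 4 gives < -3, which is a limit of the assay and not a number. Carried to a second core, the swap of 1-methyl-1-nitroethyl for (methylsulfonyl)methyl gives a number at least 1.23 log units lower from compound 2 to compound 4 (beyond the scatter), so the direction and large size of a number 1.22 log units lower from compound 1 to compound 3 (beyond the scatter) hold for both cores. How closely the two steps match cannot be said, because the second is known only as a minimum: the limit of < -3 in this assay, at which 1 of the 4 values shown sits.

Going by these compounds, this rests on just two pairs of compounds, so whether the change behaves the same way on any further core stays open. Also open, on these data alone, is how an amine or a carboxylic acid in the same place would read in this assay.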